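The source may report more compounds than this note shows. Statements on the series, on what has been measured and on what is new or still open speak of the compounds shown alone.

Measured so far:
- compound 1, `N#Cc1ccc(Nc2nccc(NCc3ccccn3)n2)cc1`: 8500 nM
- compound 2, `N#Cc1ccc(Nc2nccc(OCc3ccc(F)cc3)n2)cc1`: 81000 nM

Both numbers come from an ADME assay on MT4 cells (Homo sapiens) for cytotoxicity, read by MTT assay, with a stated time of 5 days; on this read-out higher numbers stand for lower toxicity in this test and lower numbers for higher toxicity in this test. Compound 2 gives 81000 nM, and that is the highest of the two numbers available, meaning the lower toxicity of the pair. Its nearest neighbour is compound 1, which in this assay gives 8500 nM, a clearly lower number that lies beyond the scatter of repeated measurements.

The next compound, compound 3, `N#Cc1ccc(COc2ccnc(Nc3ccc(C#N)cc3)n2)cc1`, is not yet measured. It is built from compound 2 by a single change: cyano in place of fluoro on an aromatic carbon. The fluoro that leaves is a single heavy atom; the cyano that enters brings two heavy atoms and one hydrogen-bond acceptor, placed on the same aromatic carbon, para to a large group.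

Within the data shown here, no pair of measured compounds differs in only this one place, so there is nothing in the data to show how such a swap moves the number. The expected step from compound 2 to compound 3 is therefore small, a 1.4-fold lower number from compound 2 to compound 3 (0.13 log units; within the scatter), within the scatter and with no firm direction. For compound 3 the estimate is 60000 nM, with a range from 20000 nM to 160000 nM.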

Compound 3, half-maximal cytotoxic concentration: 209000 nM
Estimate against measurement, compound 3: 3.5-fold (0.54 log units) below, and the stated range ends below it.
By their numbers in this assay, from the lowest: compound 1; then compound 2; then compound 3.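

In this assay, among these compounds, putting cyano in place of fluoro on the aromatic carbon gives a 2.6-fold higher number from compound 2 to compound 3 (0.41 log units; beyond the scatter), and this is the first measured pair that differs in only one place. The step is modest but lies beyond the scatter, so this carbon, para to a large group, is a place where a single small swap can be read in the assay: going from 4-fluorophenyl to 4-cyanophenyl moves the number up, towards lower toxicity in this test. The data offer no explanation for this rise.

Among the compounds shown here, a single pair shows only one swap on one compound, so it remains open whether another group on the same carbon, such as an amine, a carboxylic acid or a plain hydrogen, would move the number up, down or not at all. For the compounds shown here, it is equally open whether the same swap would give a step of similar size on a compound with a different side chain, such as the one carried by compound 1.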